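The source may hold more compounds than are shown below. What is called first, only, known or untested is meant among the compounds shown, and "the series" means these compounds.

Measured so far in a functional assay on MCF7 cells (Homo sapiens) for antiproliferative activity, read by MTT assay, with a stated time of 48 h; a lower number here means a stronger inhibitor, a higher number a weaker inhibitor:
compound 1 `CC(=O)Nc1nc2ccc(-c3cnc(Cl)c(NS(=O)(=O)c4ccc(F)cc4)c3)cn2n1`: 19800 nM
compound 2 `CC(=O)Nc1nc2ccc(-c3cnc(Cl)c(NS(=O)(=O)c4ccc(C)cc4)c3)cn2n1`: 3250 nM
compound 3 `COc1ncc(-c2ccc3nc(NC(C)=O)nn3c2)cc1NS(=O)(=O)c1ccc(C2CC2)cc1`: 1640 nM

Compound 1 stands highest of the three numbers. The nearest point is compound 2, reached by a 6.1-fold lower number from compound 1 to compound 2 (0.78 log units; beyond the scatter), a change on the sulfonyl aryl group. Compound 3 differs from compound 1 in several places at once, so its value is noted only as it stands.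

Compound 4 `O=C(Nc1nc2ccc(-c3cnc(Cl)c(NS(=O)(=O)c4ccc(F)cc4)c3)cn2n1)C1CC1` differs from compound 1 by cyclopropyl in place of methyl on a carbonyl carbon. Within the data shown here, no measured step touches the acetamido group; the single step in hand concerns a different part of the molecule and gives no guidance here. With nothing to lean on, a step within the scatter is the working expectation, leaning slightly toward a lower number. Compound 4 is therefore expected near 14000 nM, with a range of 5000 nM to 40000 nM. The expected step is a 1.4-fold lower number from compound 1 to compound 4 (0.15 log units; within the scatter).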

Compound 4, half-maximal inhibitory concentration: > 60000 nM
Compound 4 was reported as a limit; the forecaster's own chance of this, stated with the estimate: 10%; middle value at least 4.2-fold (0.63 log units) away from the limit.
By their numbers in this assay, from the lowest: compounds 3 and 2 (each within the scatter of the next); then compound 1. At a limit, above all of these: compound 4.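

In this assay, among these compounds, the first measured step at the acetamido group is not neutral, as compounds 1 to 3 all carry that group and could not show this: cyclopropyl in place of methyl on the carbonyl carbon gives an at least 3.0-fold higher number from compound 1 to compound 4 (0.48 log units; beyond the scatter). This single pair shows that a larger group on this carbonyl carbon can move the number upward on the core of compound 1. Compound 4 is a limit, so the full size of the step remains unknown: the limit of > 60000 nM in this assay, at which 1 of the 4 values shown sits.

Still open, on these data alone, is how a free amine or a propionyl group would read in place of the acetamido group. Also open, as far as these compounds go, is whether the same change gives a similar step with the sulfonyl aryl group of compound 2.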